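The compounds below may be only part of what the source reports. "The series", "measured", "known", "first", "only" and "open" are said of these compounds alone.

Measured so far, in an assay on Sf9 cells for inhibition of protein deacetylase HDAC6 (Homo sapiens), read by fluorescence, with a stated time of 40 min, tested at 100 nM; on this read-out lower numbers stand for less inhibition and higher numbers for more inhibition at the one concentration tested (going by the name of the read-out):

compound 1 `Cc1ccc(-c2nc(CNc3ccc(C(=O)NO)cc3)n(-c3ccccc3)n2)o1` gives 60.7%
compound 2 `O=C(O)c1ccc(NCc2nc(-c3ccccc3)nn2-c2ccccc2)cc1` gives -0.4%
compound 3 `O=C(NO)c1ccc(NCc2nc(-c3ccccc3)nn2-c2ccc(C(F)(F)F)cc2)cc1` gives 38.9%

Compound 1 stands highest of the three numbers: compound 3 comes nearest, its number lower by more than the usual scatter, and compound 2 lies furthest, lower by a wide margin. Compound 4 `O=C(NO)c1ccc(NCc2nc(-c3ccc(Cl)c(Cl)c3)nn2-c2ccccc2)cc1` has not yet been measured. It differs from compound 1 in one place: 3,4-dichlorophenyl in place of 5-methylfuran-2-yl on an aromatic carbon. Among the measured compounds shown here, no measured pair shows this exact exchange, so its size can only be guessed. Compound 3 carries a phenyl group at the same ring carbon and shows 38.9%, a number lower than that of compound 1 but well above that of compound 2. The step from compound 1 to compound 4 is expected to be a number 10.7 percentage points lower from compound 1 to compound 4 (beyond the scatter), a modest loss. Compound 4 is therefore estimated at 50%, within a range from 25% to 75%.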

Compound 4, a percentage reported as inhibition, at one concentration (the size of the read-out at that concentration, not a potency): 34.5%
Compound 4: middle estimate off by 15.5 percentage points, on the high side, and the stated range covers the measured number.
By their numbers in this assay, from the lowest: compound 2; then compounds 4 and 3 (each within the scatter of the next); then compound 1.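

In this assay, 3,4-dichlorophenyl in place of 5-methylfuran-2-yl on this aromatic carbon gives a number 26.2 percentage points lower from compound 1 to compound 4 (beyond the scatter). This shows that the group at this position matters for the read-out, with the methylfuran the better of these two. No measurement at hand explains the difference.

Going by these compounds, it remains open whether the loss follows the chlorine atoms or the change of ring; a 4-chlorophenyl group here would help separate the two. On these data alone, how an amine at this carbon would fare also remains open.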